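The compounds below may be only part of what the source reports. "The series", "measured", "known", "first", "only" and "open" are said of these compounds alone.

Compound 1 `CN1CCN(C/C=C/C(=O)Nc2cc3c(N4CCc5ccccc54)ncnc3cc2O[C@@H]2CCOC2)CC1` and compound 2 `O=C(/C=C/CN1CCC(CO)CC1)Nc1cc2c(N3CCc4ccccc43)ncnc2cc1O[C@@H]1CCOC1` share one core; compound 3 `COc1cc2ncnc(N3CCCc4ccccc43)c2cc1NC(=O)/C=C/CN1CCN(C)CC1` and compound 4 `COc1cc2ncnc(N3CCCc4ccccc43)c2cc1NC(=O)/C=C/CN1CCC(CO)CC1` share another, and the difference between the two cores is not broken down here. In a functional assay on PC-3 cells (Homo sapiens) for antiproliferative activity, read by MTT assay, with a stated time of 72 h (a lower number here means a stronger inhibitor, a higher number a weaker inhibitor), compound 1 gives 4210 nM and compound 2 gives 3310 nM, while compound 3 gives 6260 nM. The change 4-(hydroxymethyl)piperidin-1-yl in place of 4-methylpiperazin-1-yl on a saturated chain carbon bound to a double-bonded chain carbon made a 1.3-fold lower number from compound 1 to compound 2 (0.10 log units; within the scatter). The same change, (4-(hydroxymethyl)piperidin-1-yl in place of 4-methylpiperazin-1-yl on a saturated chain carbon bound to a double-bonded chain carbon), carries compound 3 to compound 4, which has not yet been measured in this assay. Resting on a 1.3-fold lower number from compound 1 to compound 2 (0.10 log units; within the scatter), a step of like size is expected for the new pair, a 1.3-fold lower number from compound 3 to compound 4 (0.12 log units; within the scatter). Compound 4 is therefore estimated at 4800 nM in this assay, with the likely span running from 2500 nM to 9500 nM.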

Compound 4, half-maximal inhibitory concentration: 7150 nM
For compound 4 the middle estimate is 1.5-fold (0.17 log units) below the measured one, and the stated range covers the measured number.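

In this assay, 4-(hydroxymethyl)piperidin-1-yl in place of 4-methylpiperazin-1-yl gives a 1.1-fold higher number from compound 3 to compound 4 (0.06 log units; within the scatter). The steps on the two cores agree: the same change on two cores in this assay, a 1.3-fold lower number (0.10 log units; within the scatter) from compound 1 to compound 2 and a 1.1-fold higher number (0.06 log units; within the scatter) from compound 3 to compound 4, 1.5-fold (0.16 log units) apart, within the scatter of two such steps

Going by these compounds alone, this shows only that the change leaves the number within the scatter on both cores; with neither step resolved, it does not show that a real effect carries over, and one pair per core says nothing about any further core. Still open, as far as these compounds go, is whether another amine on the saturated chain carbon bound to a double-bonded chain carbon, such as morpholin-4-yl or dimethylamino, would give a step beyond the scatter. The compounds shown also leave open how the two cores themselves compare, piece by piece.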